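This account rests on a few compounds, and the source may have more. Where it says the series, first, only, none or still open, it means among the compounds named here.

Compound 1 `COc1cccc(C(=O)Nc2cc(-c3ccccc3)nn2-c2ccccc2)c1`: 1290 nM
Compound 2 `O=C(Nc1cc(-c2ccccc2)nn1-c1cccc(Br)c1)c1ccccc1`: > 10000 nM
Compound 3 `N#Cc1cccc(C(=O)Nc2cc(-c3ccccc3)nn2-c2ccccc2Br)c1`: 230 nM

All three were tested in an assay on HEK293 cells for displacement of a labelled ligand from metabotropic glutamate receptor 5 (Rattus norvegicus); on this read-out lower numbers stand for stronger inhibition and higher numbers for weaker inhibition. Of the two numbers recorded, compound 1 holds the higher one, and compound 3 lies a clear gap beneath it, beyond the usual scatter. For compound 2 the assay gives no number but only (the limit of > 10000 nM in this assay, at which 1 of the 3 values shown sits).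

Compound 4 `O=C(CC1CCCC1)Nc1cc(-c2ccccc2)nn1-c1ccccc1` has not yet been measured. It differs from compound 1 by cyclopentylmethyl in place of 3-methoxyphenyl on a carbonyl carbon. Among the measured compounds shown here, no pair of measured compounds shows a change of this kind, so nothing measured here sets its size. The step is expected to run toward weaker inhibition, roughly a 3.1-fold higher number from compound 1 to compound 4 (0.49 log units; beyond the scatter), and to reach beyond the scatter. Compound 4 is estimated at 4000 nM, with a range from 1000 nM to 15000 nM.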

Compound 4, inhibition constant: > 10000 nM
Compound 4 gave a limit, no number; the forecaster's own chance of this, stated with the estimate: 35%; middle value at least 2.5-fold (0.39 log units) from the limit.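

In this assay, among the compounds shown here, this is the first readable change on the carbonyl carbon whose other neighbour is the amide-type nitrogen: cyclopentylmethyl in place of 3-methoxyphenyl gives an at least 7.7-fold higher number from compound 1 to compound 4 (0.88 log units; beyond the scatter). Compound 4 gives only a limit, not a number: the limit of > 10000 nM in this assay, at which 2 of the 4 values shown sit.

So the step has a lower bound but no known full size, and this place does not accept every ring-bearing group. The compounds shown do not tell whether the loss follows the departing aromatic ring or its oxygen. A 3-methoxybenzyl or cyclohexyl group on that carbonyl carbon would help separate these.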